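Thiourea anilides with the pyrazole substituent: methyl on the anilide

The compounds below may be only part of what the source reports. "The series", "measured", "known", "first", "only" and "open" are said of these compounds alone.

Compound 2 `CC1=C(C(=O)Nc2ccccc2)C(c2cn(-c3ccccc3)nc2-c2ccccc2)NC(=S)N1` gives 88200 nM in a functional assay on MCF7 cells (Homo sapiens) for inhibition, read by sulforhodamine B assay, with a stated time of 24 h (a higher number here means a weaker inhibitor of growth, a lower number a stronger inhibitor of growth), the highest of the three numbers measured. Among the compounds with values here, compound 1 `CCOC(=O)C1=C(C)NC(=S)NC1c1cn(-c2ccccc2)nc1-c1ccccc1` gives 42000 nM in this assay, and the step of a 2.1-fold higher number from compound 1 to compound 2 (0.32 log units; beyond the scatter) is the only single-point change measured. Compound 3 `CC1=C(C(=O)Nc2ccc(C)cc2)C(c2cn(-c3ccccc3)nc2-c2ccccc2)NC(=O)N1` gives 71700 nM in this assay; compounds 2 and 3 differ in two places, and their two values lie within the scatter of each other.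

Compound 4 `CC1=C(C(=O)Nc2ccc(C)cc2)C(c2cn(-c3ccccc3)nc2-c2ccccc2)NC(=S)N1` differs from compound 2 by methyl in place of hydrogen on an aromatic carbon. Within the data shown here, no measured step bears directly on this change: the one measured step replaces ethoxy with anilino, not hydrogen with methyl. Compound 3 carries the same methyl-bearing anilide as compound 4 and sits close to compound 2, which argues that the methyl on its own moves the number little. The expectation is therefore no step beyond the scatter, a 1.1-fold lower number from compound 2 to compound 4 (0.04 log units; within the scatter). Compound 4 is estimated at 80000 nM in this assay, with a range from 40000 nM to 160000 nM.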

Compound 4, concentration for 50% growth inhibition: 56100 nM
Compound 4: the middle estimate sits 1.4-fold (0.15 log units) above what was measured, and the stated range covers the measured number.
By their numbers in this assay, from the lowest: compounds 1, 4, 3 and 2 (each within the scatter of the next, the first and the last beyond it).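

In this assay, the series now has its first direct reading of methyl in place of hydrogen on the anilide ring: a 1.6-fold lower number from compound 2 to compound 4 (0.20 log units; within the scatter) shows that phenyl to 4-methylphenyl stays inside the scatter at this position. The replacement of ethoxy also reads differently with the methyl present, since a 2.1-fold higher number from compound 1 to compound 2 (0.32 log units; beyond the scatter) for anilino lies beyond the scatter, while a 1.3-fold higher number from compound 1 to compound 4 (0.13 log units; within the scatter) for (4-methylphenyl)amino does not. No measurement available here accounts for either reading.

Still open, on these data alone, is whether a methoxy group, a chlorine atom or a carboxylic acid in place of this methyl would give a step beyond the scatter. As far as these compounds go, it is also open whether a longer chain in place of ethoxy on the carbonyl carbon would move the number in this assay.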